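This account rests on a few compounds, and the source may have more. Where it says the series, first, only, none or still open, it means among the compounds named here.

Measured in a functional assay on ileum (Cavia porcellus) for antagonist activity; on this read-out lower numbers stand for stronger inhibition and higher numbers for weaker inhibition:
- compound 1 `Cc1cc(OCCCOc2ccccc2)cc2oc(=O)c([N+](=O)[O-])c(O)c12`: 5200 nM
- compound 2 `CCCc1c(OCCCOc2ccccc2)ccc2c(O)c([N+](=O)[O-])c(=O)oc12`: 540 nM
- compound 3 `COC(=O)c1ccc(OCCCOc2ccc3c(O)c([N+](=O)[O-])c(=O)oc3c2)cc1`: > 10000 nM

Compound 3 stands at > 10000 nM in this assay, and this value is a limit, not a number. Of the three compounds tested, only compound 1 and compound 2 have numerical values.

Compound 4 `Cc1ccc(OCCCOc2ccc3c(O)c([N+](=O)[O-])c(=O)oc3c2)cc1` differs from compound 3 by having methyl in place of methoxycarbonyl on an aromatic carbon, para to a large group (methyl in place of methoxycarbonyl on an aromatic carbon). Going by the values given here, no measured step between compounds differing in one place is available to set the size of this change. Among the compounds with values here, the only guides are compound 2 at 540 nM and compound 1 at 5200 nM. A moderate move toward stronger inhibition in this assay is expected, though compound 4 may also stay at the limit. The expected change is an at least 3.3-fold lower number from compound 3 to compound 4 (0.52 log units; beyond the scatter). For compound 4, the estimated value is 3000 nM, with an expected range of 700 nM to 10000 nM.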

Compound 4, half-maximal inhibitory concentration: 4500 nM
Beside the measured number, compound 4's estimate is 1.5-fold (0.18 log units) below it; the measured number falls inside the stated range.
By their numbers in this assay, from the lowest: compound 2; then compounds 4 and 1 (each within the scatter of the next). At a limit, above all of these: compound 3.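

With methyl in place of methoxycarbonyl on an aromatic carbon, para to a large group, this assay shows an at least 2.2-fold lower number from compound 3 to compound 4 (0.34 log units; beyond the scatter). This is the only step among the compounds shown that isolates a single change, and it shows that this position alone can separate a compound held at a limit from one with a numerical value. Compound 3 stands at a limit and not at a number, so the step can be given only as a bound: the limit of > 10000 nM in this assay, at which 1 of the 4 values shown sits.

From the compounds shown here alone, the true size of the step therefore remains open, as does whether methyl or methoxycarbonyl accounts for it, since a plain hydrogen at this carbon offers no reference here. Going by these compounds, how an amine, a carboxylic acid or a longer chain at the same position would read also remains open.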